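Fluoro in Place of Acetyl: A Second Step Expected

The source may report more compounds than this note shows. Statements on the series, on what has been measured and on what is new or still open speak of the compounds shown alone.

Compound 1, `CC(=O)c1cccc(NC(=O)N[C@H](C)c2ccccc2)c1`, in an ADME assay on the whole organism with Oryza sativa as the target, tested at 10 uM; a lower number here means a stronger effect, a higher number a weaker effect of the compound at the concentration tested: 73%
Compound 2, `CC(=O)c1ccc(NC(=O)N[C@H](C)c2ccccc2)cc1`, in this assay: 84%
Compound 3, `C[C@@H](NC(=O)Nc1cccc(F)c1)c1ccccc1`, in this assay: 84%

Compounds 1 and 3 share a core and differ in one place: fluoro in place of acetyl on an aromatic carbon. This single change moved the read-out by a number 11 percentage points higher from compound 1 to compound 3 (beyond the scatter), a step beyond the usual scatter. Compound 2 carries the same atoms as compound 1 joined differently; the difference between the two cores is not broken down here. In this assay compound 2 gives 84%, and compound 3 gives 84%, the two lying within the scatter of each other, while compound 1 gives 73%.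

Compound 4, `C[C@@H](NC(=O)Nc1ccc(F)cc1)c1ccccc1`, has not yet been measured. It stands to compound 2 as compound 3 stands to compound 1: fluoro in place of acetyl on an aromatic carbon. This is the same kind of change as the measured one, but not the same: in compound 3 the fluoro sits meta to a large group, in compound 4 it sits para to a large group. Because compound 2 already gives 84%, and because the measured step was a number 11 percentage points higher from compound 1 to compound 3 (beyond the scatter), a step of similar direction but capped by the top of the scale is expected, a number 8 percentage points higher from compound 2 to compound 4 (within the scatter). Compound 4 is therefore estimated at 92% in this assay, between 80% and 100%.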

Compound 4, a percentage reported as activity, at one concentration (the size of the read-out at that concentration, not a potency): 92%
For compound 4 middle estimate and measured number coincide at the digits printed; the range from low to high includes it.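

In this assay, fluoro in place of acetyl on an aromatic carbon, para to a large group, gives a number 8 percentage points higher from compound 2 to compound 4 (within the scatter). Set beside the step on the core of compound 1, the new step shows that the change carries across these two cores without a measurable difference in size: the same change on two cores in this assay, a number 11 percentage points higher (beyond the scatter) from compound 1 to compound 3 and a number 8 percentage points higher (within the scatter) from compound 2 to compound 4, 3 percentage points apart, within the scatter of two such steps This does not establish a general rule for the series: it rests on two pairs only, the step on the core of compound 2 cannot on its own be told apart from the scatter, and the agreement of the two steps says nothing about which part of the exchange, losing acetyl or gaining fluoro, accounts for the numbers.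

The compounds shown leave open how other groups in the same place would read out in this assay, for instance a chloro, a methoxy, a nitrile, an amine or a carboxylic acid, each of which could be set against acetyl and fluoro on both cores. They also leave open whether the same exchange would behave alike on a core altered elsewhere, such as one with a longer chain in place of the methyl group on the stereocentre.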